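A few compounds are considered here, and "the series" means these few. Any claim that something is new, unique, unknown or untested is made for them only; others in the source may bear on it.

Measured so far in an ADME assay on Vero cells (Chlorocebus sabaeus) for cytotoxicity, read by MTT assay, with a stated time of 72 h; a lower number here means a stronger inhibitor, a higher number a weaker inhibitor:
- compound 2, `COC(=O)c1ccc(-c2c(C#N)[n+]([O-])c3cc(C)ccc3[n+]2[O-])cc1`: 3.2 ug/mL
- compound 3, `COC(=O)c1ccc(-c2c(C#N)[n+]([O-])c3cc(C(F)(F)F)ccc3[n+]2[O-])cc1`: 1.93 ug/mL
- compound 1, `COc1ccc2c(c1)[n+]([O-])c(C#N)c(-c1ccccc1)[n+]2[O-]`: "nd(insoluble)" (no result reported), no number obtained

For the measured compounds named here, compound 3 holds the lowest of the two numbers; the only neighbour is compound 2, and the step of a 1.7-fold lower number from compound 2 to compound 3 (0.22 log units; within the scatter) lies within the scatter, so the two cannot be ordered. Compound 1 shares the shared core but was insoluble and gives no result.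

Compound 4, `COC(=O)c1ccc(-c2c(C#N)[n+]([O-])c3cc(OC)ccc3[n+]2[O-])cc1`, is reached from compound 3 by methoxy in place of trifluoromethyl on an aromatic carbon. Going by the values given here, the only step of any kind in this assay, a 1.7-fold lower number from compound 2 to compound 3 (0.22 log units; within the scatter), exchanged methyl for trifluoromethyl at the same carbon and stayed within the scatter; no step introduces methoxy here, and the only methoxy compound, compound 1, yielded no number. For compound 4 the expected step of a 1.6-fold higher number from compound 3 to compound 4 (0.19 log units; within the scatter) is therefore no more than the scatter, with a modest chance of a solubility-limited non-result. The estimate for compound 4 in this assay is 3 ug/mL, with a range of 1.2 ug/mL to 8 ug/mL.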

Compound 4, half-maximal inhibitory concentration: 3.9 ug/mL
For compound 4 the middle estimate is 1.3-fold (0.11 log units) below the measured one; low and high end bracket the measured number.
By their numbers in this assay, from the lowest: compounds 3, 2 and 4 (each within the scatter of the next, the first and the last beyond it).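

At this position on the aromatic carbon, this assay now shows its first step beyond the scatter (a 2.0-fold higher number from compound 3 to compound 4 (0.31 log units; beyond the scatter)), so methoxy and trifluoromethyl can be told apart here, though only modestly and on this single pair. Methoxy and methyl cannot be told apart (a 1.2-fold higher number from compound 2 to compound 4 (0.09 log units; within the scatter)), and compound 2 stays within the scatter of both compound 3 and compound 4, so the separation rests on the two end compounds alone. No measured evidence bears on why the number shifts with this exchange.

As far as these compounds go, whether this small spread holds for other groups at the same carbon, such as an amine or a carboxylic acid, remains open. Compound 1 has no number, so it offers no comparison for the methoxy group.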